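This account rests on a few compounds, and the source may have more. Where it says the series, first, only, none or still open, it means among the compounds named here.

Measured in a functional assay on PC-3 cells (Homo sapiens) for antiproliferative activity, read by MTT assay, with a stated time of 24 h; on this read-out lower numbers stand for stronger inhibition and higher numbers for weaker inhibition:
Compound 1 `CCn1c(C(=O)NCC(=O)OC)ccc1C(CC)(CC)c1ccc(OCS(=O)(=O)c2ccccc2)c(C)c1`: > 50000 nM, a limit of the assay
Compound 2 `CCn1c(C(=O)NCCNC(=O)OC(C)(C)C)ccc1C(CC)(CC)c1ccc(OCS(=O)(=O)c2ccccc2)c(C)c1`: > 50000 nM, a limit of the assay
Compound 3 `CCn1c(C(=O)N[C@H](CO)CCO)ccc1C(CC)(CC)c1ccc(OCS(=O)(=O)c2ccccc2)c(C)c1`: 12100 nM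

Compound 3 is the only one of these with an actual number, since the other two values are limits. Compound 4 `CCn1c(C(=O)N[C@@H](C)C(=O)O)ccc1C(CC)(CC)c1ccc(OCS(=O)(=O)c2ccccc2)c(C)c1` keeps the shared core and differs only on the amide-type nitrogen: 1-carboxyethyl in place of 3-hydroxy-1-(hydroxymethyl)propyl on an amide-type nitrogen. Among the compounds with values here, two measured steps bear on this change, an at least 4.1-fold lower number from compound 1 to compound 3 (0.61 log units; beyond the scatter) and an at least 4.1-fold lower number from compound 2 to compound 3 (0.61 log units; beyond the scatter). Both are beyond the scatter and both end with the group that now leaves, so a move back towards weaker inhibition is expected in this assay. The estimate must also reckon with the limit of > 50000 nM in this assay, at which 2 of the 3 values shown sit. The expected step is a 2.1-fold higher number from compound 3 to compound 4 (0.32 log units; beyond the scatter). The estimated value for compound 4 is 25000 nM, with an expected range from 9000 nM to 70000 nM.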

Compound 4, half-maximal inhibitory concentration: 16800 nM
Compound 4: the middle estimate sits 1.5-fold (0.17 log units) above what was measured; the range from low to high includes it.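

Replacing 3-hydroxy-1-(hydroxymethyl)propyl with 1-carboxyethyl on the amide-type nitrogen gives a 1.4-fold higher number from compound 3 to compound 4 (0.14 log units; within the scatter), so this assay does not separate these two groups. Within the data shown here, compound 3 is therefore no longer the only compound with an actual number, and the other comparisons give an at least 2.9-fold lower number from compound 2 to compound 4 (0.47 log units; beyond the scatter) and an at least 2.9-fold lower number from compound 1 to compound 4 (0.47 log units; beyond the scatter). Both of these steps start from a limit rather than a number: the limit of > 50000 nM in this assay, at which 2 of the 4 values shown sit.

The compounds shown leave open how a free amine or a longer chain ending in a hydroxyl on this nitrogen would read in this assay.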